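Thiophen-2-yl in Place of 3,4-Dichlorophenyl on the Carbonyl

The compounds below may be only part of what the source reports. "The series", "measured", "known", "first", "only" and "open" are said of these compounds alone.

Measured so far:
compound 1 `C=C(Br)C(=O)Nc1ccc(/C=C/C(=O)c2ccc(Cl)c(Cl)c2)cc1`: 2100 nM
compound 2 `C=C(Br)C(=O)Nc1ccc(/C=C/C(=O)c2cc(OC)c(OC)c(OC)c2)cc1`: 910 nM

In a functional assay on L1210 cells (Mus musculus) for antiproliferative activity, with a stated time of 48 h (a lower number here means a stronger inhibitor, a higher number a weaker inhibitor), compound 1 gives 2100 nM, the highest number of the two; compound 2 gives a lower number, and that gap lies beyond the scatter. Compound 3 `C=C(Br)C(=O)Nc1ccc(/C=C/C(=O)c2cccs2)cc1` is not yet measured. It differs from compound 1 in one place: thiophen-2-yl in place of 3,4-dichlorophenyl on a carbonyl carbon. Among the compounds with values here, no measured pair shows this change, so the direction is open. Compound 3 is expected near compound 1, with a step of a 1.4-fold higher number from compound 1 to compound 3 (0.15 log units; within the scatter) toward a slightly higher number, not clearly beyond the scatter. The estimate for compound 3 is 3000 nM, between 1000 nM and 9000 nM.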

Compound 3, half-maximal inhibitory concentration: 250 nM
For compound 3 the middle estimate is 12-fold (1.08 log units) above the measured one; the whole stated range lies above it.
By their numbers in this assay, from the lowest: compound 3; then compound 2; then compound 1.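

In this assay, the group on the carbonyl carbon has a clear effect: thiophen-2-yl in place of 3,4-dichlorophenyl gives an 8.4-fold lower number from compound 1 to compound 3 (0.92 log units; beyond the scatter). A six-membered aromatic ring of carbon is therefore not required at this position, and a five-membered aromatic ring with a sulfur atom can take its place with a gain in potency. No available measurement explains this gain. On these data alone, whether the sulfur atom itself matters remains open, and a furan-2-yl group, with oxygen in the ring, would test this. As far as these compounds go, whether the attachment point on the ring matters also remains open, and thiophen-3-yl would address that.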